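This account rests on a few compounds, and the source may have more. Where it says the series, first, only, none or still open, it means among the compounds named here.

Compound 1 `COc1cc(-c2cc(C(=O)O)c3ccccc3n2)ccc1OCC(=O)Nc1ccccc1` in an ADME assay on HaCaT cells (Homo sapiens) for inhibition (on this read-out higher numbers stand for weaker inhibition and lower numbers for stronger inhibition), gives > 300000 nM, which is a limit of the assay and not a number. Compound 2 `COc1cc(-c2cc(C(=O)O)c3ccccc3n2)ccc1OCC(=O)Nc1ccccc1F` gives 161000 nM. Compound 3 `COc1cc(-c2cc(C(=O)O)c3ccccc3n2)ccc1OCC(=O)Nc1cccc(Cl)c1` gives 192000 nM.

Compound 1 therefore stands at the top of the numbers shown: its value is only a limit (the limit of > 300000 nM in this assay, at which 1 of the 3 values shown sits), and what is known of it is that it lies at or beyond that limit. The steps that start from it, an at least 1.8-fold lower number from compound 1 to compound 2 (0.27 log units; that floor lies within the scatter) and an at least 1.5-fold lower number from compound 1 to compound 3 (0.19 log units; that floor lies within the scatter), are both floors whose size lies within the scatter, and the step of a 1.2-fold higher number from compound 2 to compound 3 (0.08 log units; within the scatter) is within the scatter as well. None of the three shows a movement that can be trusted.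

Compound 4 `COc1cc(-c2cc(C(=O)O)c3ccccc3n2)ccc1OCC(=O)NC1CCCCC1` differs from compound 1 by cyclohexyl in place of phenyl on an amide-type nitrogen. For the measured compounds named here, no measured step involves such a change; the measured steps concern fluoro or chloro in place of hydrogen on an aromatic carbon, or the exchange of one halogenated phenyl for another. Nothing in the data points in either direction, so no step beyond the scatter is expected. The step expected for compound 4 is a number no higher from compound 1 to compound 4 (the limit leaves the size open). Compound 4 is expected to give 300000 nM, with a range from 120000 nM to 600000 nM.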

Compound 4, half-maximal inhibitory concentration: > 300000 nM
Compound 4: only a limit was reported; the forecaster's own chance of this, stated with the estimate: 50%; the middle value sits exactly at the limit.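

In this assay compound 4 gives > 300000 nM, which is a limit of the assay and not a number. With cyclohexyl in place of phenyl on the amide-type nitrogen, the read-out stays at the same limit as for compound 1, so the step between these two cannot be read, and the data now stand as follows: the limit of > 300000 nM in this assay, at which 2 of the 4 values shown sit. The two steps that can be read are floors, an at least 1.5-fold higher number from compound 3 to compound 4 (0.19 log units; that floor lies within the scatter) and an at least 1.8-fold higher number from compound 2 to compound 4 (0.27 log units; that floor lies within the scatter), so the non-aromatic ring shows no movement that can be trusted against either halogenated phenyl.

As far as these compounds go, how a benzyl or a methyl on the amide-type nitrogen would read in this assay remains open. All the compounds shown keep the carboxylic acid of the shared core, and how a methyl ester in its place would read is open too.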